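This account rests on a few compounds, and the source may have more. Where it says the series, first, only, none or still open, it means among the compounds named here.

Compound 1 `O=C(CCc1cccc2c1B(O)OC2)NC1CCCCC1`: in an ADME assay on WI-38 cells (Homo sapiens) for cytotoxicity, read by MTT assay, with a stated time of 72 h (on this read-out lower numbers stand for stronger inhibition and higher numbers for weaker inhibition), compound 1 gives > 100000 nM, a limit of the assay rather than a number.
Compound 2 `O=C(CCc1cccc2c1B(O)OC2)NCc1ccccc1`: compound 2 likewise gives > 100000 nM, a limit.
Compound 3 `O=C(CCc1cccc2c1B(O)OC2)Nc1cccc(I)c1`: compound 3 gives 71000 nM.

Compound 3 thus holds the only number shown; the other two values are limits, as the limit of > 100000 nM in this assay, at which 2 of the 3 values shown sit, records. Compound 4 `O=C(CCc1cccc2c1B(O)OC2)Nc1cccc(-c2ccc(C(F)(F)F)cc2)c1` differs from compound 3 by 4-(trifluoromethyl)phenyl in place of iodo on an aromatic carbon. The measured steps, an at least 1.4-fold lower number from compound 1 to compound 3 (0.14 log units; that floor lies within the scatter) and an at least 1.4-fold lower number from compound 2 to compound 3 (0.14 log units; that floor lies within the scatter), concern the group on the amide-type nitrogen, not the iodo position, so none bears directly on this change, and a step that the two limits leave unreadable from compound 1 to compound 2 is unreadable. No step beyond the scatter is therefore expected, and compound 4 is estimated at 50000 nM, within 15000 nM to 150000 nM, an expected step of a 1.4-fold lower number from compound 3 to compound 4 (0.15 log units; within the scatter).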

Compound 4, half-maximal inhibitory concentration: 26000 nM
For compound 4 the middle estimate is 1.9-fold (0.28 log units) above the measured one; low and high end bracket the measured number.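

At this aromatic carbon, the change from iodo to 4-(trifluoromethyl)phenyl gives a 2.7-fold lower number from compound 3 to compound 4 (0.44 log units; beyond the scatter) in this assay, so the number responds to a change here. This is the only step shown that is readable as lying beyond the scatter, and it comes from the aromatic ring rather than the group on the amide-type nitrogen. Nothing shown explains why this step occurs.

On these data alone, it remains open whether the added ring alone carries the step or the trifluoromethyl also contributes. A plain phenyl, or a phenyl bearing an amine or a carboxylic acid, at this carbon would help separate the two.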